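The source may hold more compounds than are shown below. What is called first, only, known or untested is meant among the compounds shown, and "the series" means these compounds.

In a functional assay on DU-145 cells (Homo sapiens) for inhibition, read by trypan blue exclusion, with a stated time of 96 h (on this read-out lower numbers stand for stronger inhibition of growth and higher numbers for weaker inhibition of growth), compound 1 `O=C(/C(=C\c1ccc(O)cc1O)Sc1ccc(Br)cc1)c1ccc(Cl)cc1` gives 50000 nM, the higher of the two exact numbers, while compound 2 `Cc1ccc(C)c(/C=C(/Sc2ccc(Br)cc2)C(=O)c2ccc(Cl)cc2)c1` gives 10000 nM. Compound 3 `CN(C)c1ccc(/C=C(/Sc2ccc(Br)cc2)C(=O)c2ccc(Cl)cc2)cc1` reaches only a limit of the assay, > 100000 nM. Compound 4 `O=C(/C(=C\c1ccc(O)cc1O)Sc1ccccc1Br)c1ccc(Cl)cc1` has 2-bromophenyl in place of 4-bromophenyl on a sulfur. Among the compounds with values here, no measured step changes this group. Each one alters the group on a double-bonded chain carbon instead, giving a 5.0-fold lower number from compound 1 to compound 2 (0.70 log units; beyond the scatter) and an at least 10-fold higher number from compound 2 to compound 3 (1.00 log units; beyond the scatter). These steps show that the numbers can move within this small set, but they do not measure this swap, so no step beyond the scatter is expected, in either direction. The expected change is a 1.3-fold lower number from compound 1 to compound 4 (0.10 log units; within the scatter). For compound 4, the estimated value is 40000 nM, with an expected range of 12000 nM to 100000 nM.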

Compound 4, concentration for 50% growth inhibition: 50000 nM
For compound 4 the middle estimate is 1.3-fold (0.10 log units) below the measured one; low and high end bracket the measured number.
By their numbers in this assay, from the lowest: compound 2; then compounds 1 and 4 (each within the scatter of the next). At a limit, above all of these: compound 3.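

Putting 2-bromophenyl in place of 4-bromophenyl on a sulfur gives no change at the digits printed from compound 1 to compound 4 (within the scatter) in this assay. Within the data shown here, this is the first measured step at this group, since the earlier steps altered only the group on the double-bonded chain carbon, and it holds only with the 2,4-dihydroxyphenyl group in place. Neither compound 1 nor compound 4 sits at the assay's limit, which belongs to compound 3 alone: the limit of > 100000 nM in this assay, at which 1 of the 4 values shown sits.

On these data alone, whether an amine or a carboxylic acid in place of the bromine would shift the number remains open. So does whether the same swap would matter with the 2,5-dimethylphenyl group of compound 2.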